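The source may hold more compounds than are shown below. What is called first, only, known or untested is meant among the compounds shown, and "the series" means these compounds.

Measured in an assay on Sf9 cells for inhibition of mitogen-activated protein kinase kinase kinase 20 (Homo sapiens), read by ADP-Glo, with a stated time of 30 min; a lower number here means a stronger inhibitor, a higher number a weaker inhibitor:

Compound 1 `COc1n[nH]c2ncc(C#Cc3c(F)ccc(NS(=O)(=O)c4cccc(Cl)c4)c3F)cc12`: compound 1 gives 14.7 nM.
Compound 2 `COc1n[nH]c2ncc(-c3cn(-c4c(F)ccc(NS(=O)(=O)c5cccc(Cl)c5)c4F)nn3)cc12`: compound 2 gives 1.9 nM.
Compound 3 `Nc1ccc(-c2cn(-c3c(F)ccc(NS(=O)(=O)c4cccc(Cl)c4)c3F)nn2)cn1`: compound 3 gives 46.2 nM.

Among these three, compound 3 has the highest number in this assay: it sits beyond the scatter above compound 1 and well above compound 2. Among the measured compounds shown here, the only single-point change recorded so far is a 24-fold higher number from compound 2 to compound 3 (1.39 log units; beyond the scatter), where the group on the five-membered ring bearing the sulfonamide-carrying aryl was exchanged wholesale, and this step was large.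

Compound 4 `Nc1ncc(-c2cn(-c3c(F)ccc(NS(=O)(=O)c4cccc(Cl)c4)c3F)nn2)cn1` differs from compound 3 by 2-aminopyrimidin-5-yl in place of 6-aminopyridin-3-yl on an aromatic carbon. For the measured compounds named here, only one measured step touches this part of the molecule, and that step replaced an entire bicyclic group with a smaller monocyclic one; it is therefore only loosely related to the present exchange, which keeps the size and donor count of the group and changes one ring atom. Going by the values given here, no measured pair shows the effect of such a ring-atom change, so there is no direct precedent for its size or direction.

Given this, the change is expected to produce no step beyond the scatter, with a slight lean towards a higher number, and the step of a 1.2-fold higher number from compound 3 to compound 4 (0.08 log units; within the scatter) is the estimate. For compound 4 the expected value in this assay is 55 nM, with a likely range from 20 nM to 160 nM.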

Compound 4, half-maximal inhibitory concentration: 8.9 nM
The estimate for compound 4 lay 6.2-fold (0.79 log units) above the measured number; measured number below the stated range.
By their numbers in this assay, from the lowest: compound 2; then compounds 4 and 1 (each within the scatter of the next); then compound 3.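

In this assay, exchanging 6-aminopyridin-3-yl for 2-aminopyrimidin-5-yl gives a 5.2-fold lower number from compound 3 to compound 4 (0.72 log units; beyond the scatter), which shows that a single ring-atom change in a group of the same heavy-atom count, on this aromatic carbon of the five-membered aromatic ring with 3 nitrogen, can move the number beyond the scatter. It also shows that the penalty for leaving the bicyclic group of compound 2 depends on which monocyclic group enters: the step is a 4.7-fold higher number from compound 2 to compound 4 (0.67 log units; beyond the scatter), against a 24-fold higher number from compound 2 to compound 3 (1.39 log units; beyond the scatter) for the aminopyridine. The data at hand offer nothing that explains why the extra ring nitrogen goes with the lower number.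

As far as these compounds go, what a plain pyrimidin-5-yl or a 2-(methylamino)pyrimidin-5-yl would give at this place remains open, so the part played by the amine on the pyrimidine ring is unknown. Also open, from the compounds shown here alone, is whether the same ring-atom change would have a similar effect with a different aryl group on the sulfonamide, as this single pair shares one sulfonamide and one linking ring.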